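The source may report more compounds than this note shows. Statements on the series, on what has been measured and on what is new or still open speak of the compounds shown alone.

Measured so far:
compound 1, `Cc1ccccc1S(=O)(=O)NC(=O)c1ccc(Nc2nc(NC3(c4ccc(Cl)cc4)CC3)nc(OCC(F)(F)F)n2)cc1`: 100%
compound 2, `CS(=O)(=O)NC(=O)c1ccc(Nc2nc(NC3(c4ccc(Cl)cc4)CC3)nc(OCC(F)(F)F)n2)cc1`: 100%

For the measured compounds named here, in an ADME assay on microsomes from liver (Homo sapiens) for metabolic stability, with a stated time of 10 min (a lower number here means that less of the compound is left, a higher number that more of the compound is left), compound 2 stands level with compound 1, and the one measured step, no change at the digits printed from compound 1 to compound 2 (within the scatter), lay within the scatter. Compound 3, `CC(C)NCCS(=O)(=O)NC(=O)c1ccc(Nc2nc(NC3(c4ccc(Cl)cc4)CC3)nc(OCC(F)(F)F)n2)cc1`, differs from compound 2 by (isopropylamino)methyl in place of hydrogen on a saturated chain carbon bound to a sulfonyl sulfur. Going by the values given here, only that single step bears on this part of the molecule, and it showed that replacing the group on the sulfonyl sulfur left the read-out unchanged. The expected step of a number 3 percentage points lower from compound 2 to compound 3 (within the scatter) is therefore none beyond the scatter. Compound 3 is estimated at 97%, within a range of 85% to 100%.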

Compound 3, percent of the compound remaining: 89%
For compound 3 the middle estimate is 8 percentage points above the measured one; the measured number falls inside the stated range.
By their numbers in this assay, from the lowest: compound 3; then compounds 1 and 2 (each within the scatter of the next).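

In this assay, the group on the sulfonyl sulfur now registers: 2-(isopropylamino)ethyl in place of methyl gives a number 11 percentage points lower from compound 2 to compound 3 (beyond the scatter), and the same chain in place of 2-methylphenyl gives a number 11 percentage points lower from compound 1 to compound 3 (beyond the scatter). This position, unchanged by the earlier exchange of 2-methylphenyl for methyl, therefore does respond to this amine-bearing chain, though modestly. No measurement here explains the step. Still open, going by these compounds, is whether the amine or the chain itself matters: a plain alkyl chain, a 2-hydroxyethyl group or a carboxylic acid at this place could separate the two.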